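Swapping One Halogen for Another on Compound 2

A few compounds are considered here, and "the series" means these few. Any claim that something is new, unique, unknown or untested is made for them only; others in the source may bear on it.

Going by the values given here, compound 2 `O=C(/C=C/c1ccc(F)c(F)c1)c1ccc(B(O)O)cc1` is one of two compounds measured in a functional assay on MCF-12A cells (Homo sapiens) for inhibition (on this read-out lower numbers stand for stronger inhibition and higher numbers for weaker inhibition), and of these two it has the highest number: in this assay compound 2 gives 39000 nM. Its nearest neighbour is compound 1 `O=C(/C=C/c1ccc(F)c(Cl)c1)c1ccc(B(O)O)cc1`, which in this assay gives 22000 nM. Among the compounds with values here, the single step between them, a 1.8-fold higher number from compound 1 to compound 2 (0.25 log units; within the scatter), lies within the scatter, so the two compounds cannot be told apart on this read-out.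

Compound 3 `O=C(/C=C/c1ccc(F)c(Br)c1)c1ccc(B(O)O)cc1` has not yet been measured. Its change from compound 2 is bromo in place of fluoro on an aromatic carbon. Within the data shown here, the only measured step that bears on it is the earlier halogen exchange, a 1.8-fold higher number from compound 1 to compound 2 (0.25 log units; within the scatter), which itself stayed within the scatter. No step beyond the scatter is therefore expected in this assay. If anything, a drift back toward the number of compound 1 is expected. The expected step is a 1.8-fold lower number from compound 2 to compound 3 (0.25 log units; within the scatter). The estimate for compound 3 is 22000 nM, with a range from 8000 nM to 55000 nM.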

Compound 3, half-maximal inhibitory concentration: 38000 nM
Compound 3: the middle estimate sits 1.7-fold (0.24 log units) below what was measured; the measured number falls inside the stated range.
By their numbers in this assay, from the lowest: compounds 1, 3 and 2 (each within the scatter of the next).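

With bromo, this aromatic carbon has now carried three different halogens. In this assay the exchange of fluoro for bromo gives a 1.0-fold lower number from compound 2 to compound 3 (0.01 log units; within the scatter) and the exchange of chloro for bromo gives a 1.7-fold higher number from compound 1 to compound 3 (0.24 log units; within the scatter) at the same place, so all three compounds lie within the scatter of one another and this read-out cannot tell fluoro, chloro and bromo apart here, even across the full set of pairs. No measurement is at hand that would explain this flat result.

The compounds shown leave open whether a group of another kind on this carbon, such as an amine, a methoxy group or a carboxylic acid, would move the number beyond the scatter. They also leave open whether halogens placed elsewhere on this ring would behave the same way.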